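The source may report more compounds than this note shows. Statements on the series, on what has been measured and on what is new or still open speak of the compounds shown alone.

Measured compounds:
Compound 1, `O=C(Nc1ccc(Cl)c(-c2nnc3c(Cl)cccn23)c1)c1ccccc1`: in a functional assay on MDA-MB-468 cells (Homo sapiens) for antiproliferative activity, read by MTT assay, with a stated time of 72 h (a lower number here means a stronger inhibitor, a higher number a weaker inhibitor), compound 1 gives > 100000 nM, which is a limit of the assay rather than a number.
Compound 2, `Cc1cc(Cl)ccc1C(=O)Nc1ccc(Cl)c(-c2nnc3c(Cl)cccn23)c1`: in this assay compound 2 gives 34300 nM.

Among the compounds with values here, the only measured step is an at least 2.9-fold lower number from compound 1 to compound 2 (0.46 log units; beyond the scatter). Within the data shown here, compound 2 therefore holds the sole numeric value shown, the other value being a limit (the limit of > 100000 nM in this assay, at which 1 of the 2 values shown sits). Compound 3, `CS(=O)(=O)c1cccc(C(=O)Nc2ccc(Cl)c(-c3nnc4c(Cl)cccn34)c2)c1`, differs from compound 2 by 3-(methylsulfonyl)phenyl in place of 4-chloro-2-methylphenyl on a carbonyl carbon. The step from compound 1 to compound 2 changed the group on the same carbonyl carbon, but to a different group, so it gives no direction for 3-(methylsulfonyl)phenyl; it only shows that this position can shift activity by a modest amount. No step beyond the scatter is expected in either direction, and the estimated step is a 1.2-fold higher number from compound 2 to compound 3 (0.07 log units; within the scatter). Compound 3 is expected to give 40000 nM in this assay, within a range of 8000 nM to 100000 nM.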

Compound 3, half-maximal inhibitory concentration: > 100000 nM
Compound 3 was reported as a limit; the forecaster's own chance of this, stated with the estimate: 35%; at least 2.5-fold (0.39 log units) between middle value and limit.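

Putting 3-(methylsulfonyl)phenyl in place of 4-chloro-2-methylphenyl on the carbonyl carbon gives an at least 2.9-fold higher number from compound 2 to compound 3 (0.46 log units; beyond the scatter), so a substituent on the phenyl ring at this position does not by itself yield a measurable number. Compound 3 gives > 100000 nM in this assay, which is a limit of the assay and not a number. The step from compound 1 to compound 3 cannot be read, and most of the series now sits at one end of the scale: the limit of > 100000 nM in this assay, at which 2 of the 3 values shown sit.

The compounds shown leave open whether the chlorine, the methyl or both together in 4-chloro-2-methylphenyl account for the measurable value of compound 2. They also leave open what an amine or a carboxylic acid on this phenyl ring would do.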